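From benzoyl to carboxy on a shared core

The compounds below may be only part of what the source reports. "The series", "measured", "known", "first", "only" and "open" are said of these compounds alone.

Values in a functional assay on Raji cells (Homo sapiens) for cytotoxicity, with a stated time of 72 h (on this read-out lower numbers stand for an effect already at smaller amounts and higher numbers for an effect only at larger amounts of compound), follow
Compound 1 `C=C[C@@](C)(/C=C/c1ccc(O)cc1)CCC1OC1(C)C` gives > 22500 nM
Compound 2 `C=C[C@@](C)(/C=C/c1ccc(O)c(/C=C/C(=O)c2ccccc2)c1)CCC=C(C)C` gives > 26000 nM

In this assay compound 2 stands only at the limit > 26000 nM and has no number. Compound 1 also reaches only a limit, at > 22500 nM in this read-out. Compound 3 `C=C[C@@](C)(/C=C/c1ccc(O)c(/C=C/C(=O)O)c1)CCC=C(C)C` carries hydroxy in place of phenyl on a carbonyl carbon, which also reads as benzoyl to carboxy. Going by the values given here, no measured step bears on this change. The expected step that the limit leaves unreadable from compound 2 to compound 3 stays within the scatter, in neither direction, in this assay as far as can be estimated. Compound 3 is estimated at 28000 nM with an expected range from 13000 nM to 60000 nM in this measurement.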

Compound 3, half-maximal effective concentration: > 26000 nM
Compound 3: a limit, no number (the forecaster's own chance of this, stated with the estimate: 75%); the middle value does not contradict the limit.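

Going by these compounds alone, compound 2 and compound 3 both stand only at a limit in this assay, and no step between them can be read. The compounds shown leave open whether benzoyl to carboxy changes this read-out at all.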